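The source may hold more compounds than are shown below. What is called first, only, known or untested is meant among the compounds shown, and "the series" means these compounds.

In an ADME assay on L6 cells (Rattus norvegicus) for cytotoxicity, read by resazurin assay, with a stated time of 70 h (a higher number here means a weaker inhibitor, a lower number a stronger inhibitor), compound 1 `COc1ccc(/C=C/C(=O)NCCCC(C)Nc2cc(OC)cc3cccnc23)cc1` gives > 100 ug/mL. This is a limit of the assay and not a number, so any step starting from compound 1 has only a bound on its size. Compound 2 `COc1cc(NC(C)CCCNC(=O)/C=C/c2cccc(C(F)(F)F)c2)c2ncccc2c1`, with 3-(trifluoromethyl)phenyl in place of 4-methoxyphenyl, gives 7.4 ug/mL.

The next compound is compound 3 `COc1cc(NC(C)CCCNC(=O)Nc2cccc(F)c2)c2ncccc2c1`. The change is (3-fluorophenyl)amino in place of 2-(4-methoxyphenyl)ethenyl on a carbonyl carbon: (3-fluorophenyl)amino in place of 2-(4-methoxyphenyl)ethenyl, on a carbonyl carbon. For the measured compounds named here, the 4-methoxyphenyl group therefore goes here too, and the one measured step that bears on this is an at least 13-fold lower number from compound 1 to compound 2 (1.13 log units; beyond the scatter), a large one. It remains a single step with a different entering group, and the double bond stays in that pair but leaves in this one. Only part of its size is therefore carried over, and the direction is kept, towards a lower number in this assay. The estimated step is an at least 4.0-fold lower number from compound 1 to compound 3 (0.60 log units; beyond the scatter). For compound 3 the expected value is 25 ug/mL, with an estimated range from 6 ug/mL to 90 ug/mL.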

Compound 3, half-maximal inhibitory concentration: 9.18 ug/mL
Estimate against measurement, compound 3: 2.7-fold (0.44 log units) above; measured number inside the range.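

In this assay the position on the carbonyl carbon now has two different replacements for 2-(4-methoxyphenyl)ethenyl, and both are linked to a lower number; with (3-fluorophenyl)amino, the step is an at least 10-fold lower number from compound 1 to compound 3 (1.03 log units; beyond the scatter). The lower number therefore does not depend on keeping the double bond outside the aromatic ring or on trifluoromethyl, as the urea-type link in compound 3 carries neither, and compound 2 gives 7.4 ug/mL while compound 3 gives 9.18 ug/mL. Both steps start from a limit held by compound 1, so their sizes are bounds and not measured differences: the limit of > 100 ug/mL in this assay, at which 1 of the 3 values shown sits.

The compounds shown do not separate the loss of 4-methoxyphenyl from the change of link, as the ring and the link change together in compound 3. (4-Methoxyphenyl)amino on the same carbonyl carbon, or 2-(3-fluorophenyl)ethenyl in that place, would divide these two changes, and an unsubstituted phenyl ring on either link would show whether methoxy, fluorine or trifluoromethyl matters at all.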